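A Chloro for Methyl Swap at the Assay Limit

A few compounds are considered here, and "the series" means these few. Any claim that something is new, unique, unknown or untested is made for them only; others in the source may bear on it.

In a functional assay on HeLa cells (Homo sapiens) for cytotoxicity, read by MTT assay, with a stated time of 72 h (a higher number here means a weaker inhibitor, a lower number a stronger inhibitor), compound 1 `CCOC(=O)c1csc2nc(-c3cccc(NC(=O)CC)c3)cn12` gives > 20000 nM, which is a limit and not a number. Compound 2 `CCOC(=O)c1csc2nc(-c3ccc(NS(=O)(=O)c4ccc(C)cc4)cc3)cn12` gives > 20000 nM, which is also a limit. Compound 3 `CCOC(=O)c1csc2nc(-c3ccc(NC(=O)c4ccco4)cc3)cn12` gives > 20000 nM, again a limit. Among the measured compounds shown here, compound 1 therefore has no number of its own, and the series so far shows only (the limit of > 20000 nM in this assay, at which 3 of the 3 values shown sit).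

Compound 4 `CCOC(=O)c1csc2nc(-c3cccc(NC(=O)CCl)c3)cn12` keeps the core of compound 1 and differs from it in one place: chloro in place of methyl on a saturated chain carbon bound to a carbonyl carbon. This puts chloro in place of methyl on a saturated chain carbon bound to a carbonyl carbon, so that propanoylamino becomes ((chloromethyl)carbonyl)amino.

For the measured compounds named here, only one measured step changes a single place, a step that the two limits leave unreadable from compound 2 to compound 3. It concerns a different group on a nitrogen on an aromatic ring and offers no size to carry over. Going by the values given here, no measured step involves chloro or methyl. On these data, no step beyond the scatter is expected in this assay, and any shift would be expected towards a stronger inhibitor. The expected step is a number no higher from compound 1 to compound 4 (the limit leaves the size open). Compound 4 may also return only a limit. Compound 4 is estimated at 20000 nM, with an expected range of 7000 nM to 30000 nM.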

Compound 4, half-maximal inhibitory concentration: 20000 nM
For compound 4 middle estimate and measured number coincide at the digits printed, within the range that was stated.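

Among the compounds shown here, the change of methyl to chloro on a saturated chain carbon bound to a carbonyl carbon is the first change here that ends on a measured number in this assay, with compound 4 at 20000 nM. Set against compound 1, the change reads as a number no higher from compound 1 to compound 4 (the limit leaves the size open), so this position gives a direction at most, and even that rests on a single pair of compounds. It does not move the series clear of the ceiling of the assay, and compound 4 stands as the only exact value among the compounds shown, the others being held at: the limit of > 20000 nM in this assay, at which 3 of the 4 values shown sit.

The compounds shown leave open whether any group at this position can bring a number well clear of that ceiling, for instance bromo in place of chloro, an amine in place of chloro, or a longer chain carrying the chloro at its end. They also leave open whether the ((chloromethyl)carbonyl)amino group would give a readable number on the other arrangements of the shared core, such as the furan-2-yl carbonyl amide of compound 3.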